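The source may hold more compounds than are shown below. What is called first, only, known or untested is meant among the compounds shown, and "the series" means these compounds.

Working notes on the series. Three compounds share one core and differ only in the substituent on the aromatic carbon of that core. In an assay for inhibition of beta-galactosidase (Bos taurus), tested at 1 mM (a lower number here means less inhibition, a higher number more inhibition at the concentration tested (going by the name of the read-out)), compound 1 `COC(=O)c1cc(C2NCC(O)C2O)oc1C` gives 54%, compound 2 `Cc1oc(C2NCC(O)C2O)cc1CO` gives 50% and compound 3 `Cc1oc(C2NCC(O)C2O)cc1C(=O)O` gives 30%. Compound 3 is the lowest of the three: the step of a number 24 percentage points lower from compound 1 to compound 3 (beyond the scatter) and the step of a number 20 percentage points lower from compound 2 to compound 3 (beyond the scatter) are both beyond the scatter, whereas the step of a number 4 percentage points lower from compound 1 to compound 2 (within the scatter) is within it.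

Compound 4 `Cc1oc(C2NCC(O)C2O)cc1C(=O)Nc1ccccc1` is not yet measured. Its change from compound 3 is anilino in place of hydroxy on a carbonyl carbon. Among the compounds with values here, two measured steps bear on this: the carboxy of compound 3 arrived through a number 20 percentage points lower from compound 2 to compound 3 (beyond the scatter), and the same carboxy was also reached through a number 24 percentage points lower from compound 1 to compound 3 (beyond the scatter), where a hydrogen replaced the methyl on the oxygen next to the carbonyl group. Both steps into the free carboxy lowered this assay by a modest amount, so the step away from it, with an anilino entering on the carbonyl carbon, is expected to recover a number of comparable size, upward, as a number 20 percentage points higher from compound 3 to compound 4 (beyond the scatter). For compound 4 this assay is therefore estimated at 50%, within a range of 30% to 70%.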

Compound 4, a percentage reported as inhibition, at one concentration (the size of the read-out at that concentration, not a potency): 39%
For compound 4 the middle estimate is 11 percentage points above the measured one; the measured number falls inside the stated range.
By their numbers in this assay, from the lowest: compounds 3 and 4 (each within the scatter of the next); then compounds 2 and 1 (each within the scatter of the next).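

On the carbonyl carbon, anilino in place of hydroxy gives a number 9 percentage points higher from compound 3 to compound 4 (within the scatter) in this assay and so brings in 7 heavy atoms and a six-membered aromatic ring of carbon only without a change beyond the usual scatter. Within the data shown here, the number in this assay therefore stays level with a much larger substituent than the earlier compounds carried, at least in this one reading, and the anilino and hydroxy forms cannot be ordered. Anilino in place of methoxy on the same carbon gives a number 15 percentage points lower from compound 1 to compound 4 (beyond the scatter) and adds what the earlier steps could not show: the gap to compound 1 is not confined to the free carboxy of compound 3 but also appears with the anilide, and no measurement at hand accounts for either step.

Open, as far as these compounds go, is whether an unsubstituted carboxamide, a methylamino group or a benzylamino group on the carbonyl carbon would read with compound 3 and compound 4 or with compound 1. Since each reading comes from a single concentration, the potency of these compounds also remains open.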